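The source may report more compounds than this note shows. Statements on the series, on what has been measured and on what is new or still open speak of the compounds shown alone.

Among the measured compounds shown here, compound 1, `COc1cc2c(Nc3ccc(B(O)O)cc3)ncnc2c(OC)c1OC`, is the only member of the series with a numerical reading: in a functional assay on SGC-7901 cells (Homo sapiens) for antiproliferative activity, read by MTT assay, with a stated time of 72 h (on this read-out higher numbers stand for weaker inhibition and lower numbers for stronger inhibition), compound 1 gives 434 nM. Compound 2, `COc1cc2c(Nc3cccc(Br)c3F)ncnc2c(OC)c1OC`, gives in this assay only a limit of > 30000 nM, which is the limit of > 30000 nM in this assay, at which 1 of the 2 values shown sits. For the measured compounds named here, no pair of measured compounds differs in a single place, so no measured step exists.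

Compound 3, `COc1cc2c(Nc3ccc(C(F)(F)F)cc3)ncnc2c(OC)c1OC`, departs from compound 1 by a group of 4 heavy atoms (1 carbon, 3 fluorine; no ring) in place of a group of 3 heavy atoms (1 boron, 2 oxygen; no ring), on an aromatic carbon. A moderate loss is expected, a 3.5-fold higher number from compound 1 to compound 3 (0.54 log units; beyond the scatter). Compound 3 is estimated at 1500 nM, between 300 nM and 8000 nM.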

Compound 3, half-maximal inhibitory concentration: > 30000 nM
Compound 3: only a limit was reported; the forecaster's own chance of this, stated with the estimate: 15%; middle value at least 20-fold (1.30 log units) away from the limit.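

In this assay, trifluoromethyl in place of the group of boron and oxygen, on an aromatic carbon para to a large group, gives an at least 69-fold higher number from compound 1 to compound 3 (1.83 log units; beyond the scatter). Compound 3 gives only a limit, > 30000 nM, not a number. This position therefore does not tolerate every group, and most readings in the series now sit at one limit: the limit of > 30000 nM in this assay, at which 2 of the 3 values shown sit.

Going by these compounds, whether activity needs boron itself or only a group with hydrogen-bond donors stays open. A carboxylic acid or an amine on this carbon would separate the two.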